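The compounds below may be only part of what the source reports. "The series", "measured", "known", "first", "only" and "open" are said of these compounds alone.

Three compounds have been measured in a functional assay on the whole organism with Mus musculus as the target, in the rotarod test; a higher number here means that more compound is needed for the effect, a lower number that less compound is needed:

Compound 1, `NCC(=O)NCC(=O)Nc1ccc([N+](=O)[O-])cc1C(=O)c1ccccc1`, gives 24.8 mg/kg.
Compound 2, `CN(C(=O)CNC(=O)CN)c1ccc([N+](=O)[O-])cc1C(=O)c1ccccc1`, gives 2.94 mg/kg.
Compound 3, `CC(=O)NCC(=O)N(C)c1ccc(Cl)cc1C(=O)c1ccccc1Cl`, gives 58 mg/kg.

Compound 1 differs from compound 2 only by hydrogen in place of methyl on an amide-type nitrogen, and that single change made a step of an 8.4-fold higher number from compound 2 to compound 1 (0.93 log units; beyond the scatter). Compound 3 carries a different core; how its core differs from that of compound 2 is not broken down here, and its values simply show that it needed the most compound of the three in this assay.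

Compound 4, `CC(=O)NCC(=O)Nc1ccc(Cl)cc1C(=O)c1ccccc1Cl`, is still unmeasured. It differs from compound 3 by hydrogen in place of methyl on an amide-type nitrogen, the same change, at the same kind of place, that turned compound 2 into compound 1. Since that change pushed the number up by an 8.4-fold higher number from compound 2 to compound 1 (0.93 log units; beyond the scatter), a step of comparable direction from compound 3 to compound 4 is expected, though the different core leaves its exact size uncertain; the expected step is a 4.3-fold higher number from compound 3 to compound 4 (0.63 log units; beyond the scatter). For compound 4 the estimate in this assay is therefore 250 mg/kg, expected to lie between 80 mg/kg and 800 mg/kg.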

Compound 4, dose for half-maximal effect: > 100 mg/kg
Compound 4 gave a limit, no number; the forecaster's own chance of this, stated with the estimate: 30%; the middle value does not contradict the limit.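

In this assay compound 4 gives > 100 mg/kg, which is a limit of the assay and not a number. Putting hydrogen in place of methyl on the amide-type nitrogen therefore gives an at least 1.7-fold higher number from compound 3 to compound 4 (0.23 log units; that floor lies within the scatter), a result that fits the rise seen on the other core but does not by itself prove a real rise on this one. The change can thus be carried across the two cores only in a loose sense, since the true size of the second step stays unknown: the same change on two cores in this assay, an 8.4-fold higher number (0.93 log units; beyond the scatter) from compound 2 to compound 1 and an at least 1.7-fold higher number (0.23 log units; that floor lies within the scatter) from compound 3 to compound 4; the limit leaves it open whether they differ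

The compounds shown leave open what an ethyl group or a longer chain on that same nitrogen would do in place of methyl, as only methyl and hydrogen appear there. They also leave open which parts of the two cores account for the gap between the methyl compounds, since compound 2 and compound 3 differ in more than one place.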